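The source may hold more compounds than are shown below. What is called first, only, known or untested is meant among the compounds shown, and "the series" means these compounds.

Measured compounds:
- compound 1, `COc1ccc(/C=C\c2cc(OC)c(OC)c(OC)c2)cc1OCc1ccc(CNC(C)(C)C(=O)O)cc1`, gives 6500 nM in a functional assay on HepG2 cells (Homo sapiens) for antiproliferative activity, read by CCK-8 assay, with a stated time of 48 h; on this read-out higher numbers stand for weaker inhibition and lower numbers for stronger inhibition.
- compound 2, `COc1ccc(/C=C\c2cc(OC)c(OC)c(OC)c2)cc1OCc1ccc(CN2CCCC[C@H]2C(=O)O)cc1`, gives only a limit of the assay in this assay: > 10000 nM.
- compound 3, `COc1ccc(/C=C\c2cc(OC)c(OC)c(OC)c2)cc1OCc1ccc(CNCCO)cc1`, gives 5900 nM in this assay.

All three share one core and differ only in the group carried on the saturated chain carbon bound to an aromatic carbon. Among the numbers shown, compound 1 has the highest, and compound 3 lies within the scatter of it, so the two cannot be ranked. For compound 2 the result is a limit and not a number (the limit of > 10000 nM in this assay, at which 1 of the 3 values shown sits).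

Compound 4, `COc1ccc(/C=C\c2cc(OC)c(OC)c(OC)c2)cc1OCc1ccc(CO)cc1`, has not yet been measured. hydroxy in place of (1-carboxy-1-methylethyl)amino on a saturated chain carbon bound to an aromatic carbon

Among the compounds with values here, two measured steps touch the same position. The step of a 1.1-fold lower number from compound 1 to compound 3 (0.04 log units; within the scatter) shows that exchanging the group on the amine nitrogen left the number where it was. The step of an at least 1.5-fold higher number from compound 1 to compound 2 (0.18 log units; that floor lies within the scatter) ended at the limit. Within the data shown here, neither removes the amine nitrogen altogether, as the change to compound 4 does, so no measured step matches it exactly. With the step to compound 3 flat, the expectation is a step of no more than the scatter: a 1.3-fold lower number from compound 1 to compound 4 (0.11 log units; within the scatter). Compound 4 is therefore estimated to give 5000 nM, expected to fall between 1500 nM and 15000 nM.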

Compound 4, half-maximal inhibitory concentration: 2400 nM
Compound 4: middle estimate off by 2.1-fold (0.32 log units), on the high side, within the range that was stated.
By their numbers in this assay, from the lowest: compound 4; then compounds 3 and 1 (each within the scatter of the next). At a limit, above all of these: compound 2.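

Until now, exchanging the group on the amine nitrogen had produced no step beyond the scatter, but removing that nitrogen together with its substituent and leaving only a hydroxy on the saturated chain carbon gives a 2.7-fold lower number from compound 1 to compound 4 (0.43 log units; beyond the scatter). The same replacement starting from compound 3, which carries a 2-hydroxyethyl group in place of the carboxylic acid-bearing group of compound 1, gives a 2.5-fold lower number from compound 3 to compound 4 (0.39 log units; beyond the scatter), so in this assay the lower number appears from both of these amines and does not depend on which of the two groups leaves. With compound 2 the replacement gives an at least 4.1-fold lower number from compound 2 to compound 4 (0.61 log units; beyond the scatter), which is a floor and not a measured size, as compound 2 stands at a limit: the limit of > 10000 nM in this assay, at which 1 of the 4 values shown sits.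

The compounds shown cannot separate an effect of the hydroxy itself from an effect of losing the amine nitrogen and its substituent. From the compounds shown here alone, a methoxy, a plain primary amine or a carboxylic acid on the same saturated chain carbon would address this, and how far the number can fall at this position remains open.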